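The source may hold more compounds than are shown below. What is called first, only, known or untested is meant among the compounds shown, and "the series" means these compounds.

Measured compounds in the series:
- compound 1, `CO[C@H]1CC[C@@H](CN2CC(=O)Nc3ncc(-c4ccc(C(C)(C)O)nc4)nc32)CC1`: "not determined" (no result reported) in an ADME assay on the whole organism for pharmacokinetics, with Rattus norvegicus as the target, at a dose of 5 mg/kg by the oral route; on this read-out lower numbers stand for lower exposure and higher numbers for higher exposure at the dose given
- compound 2, `CO[C@H]1CC[C@H](N2CC(=O)Nc3ncc(-c4ccc(C(C)(C)O)nc4)nc32)CC1`: 35800 ng.h/mL
- compound 3, `CC(C)(O)c1ccc(-c2cnc3c(n2)N(CC2CCCCC2)CC(=O)N3)cn1`: "not determined" (no result reported) in this assay

Compound 3 stands without a number: in this assay it has no reported value, and compound 1 likewise has none, so compound 2 alone gives the series a figure, with compound 2 at 35800 ng.h/mL. Compound 4, `CO[C@H]1CC[C@@H](N2CC(=O)Nc3ncc(-c4ccc(C(C)(C)O)nc4)nc32)CC1`, is to be measured in this assay. It differs from compound 3 in one place: 4-methoxycyclohexyl in place of cyclohexylmethyl on a nitrogen on an aromatic ring in a ring. For the measured compounds named here, no step between measured compounds is in hand, so the size of this change in this assay cannot be read from the series; with only compound 2 carrying a number, the expectation rests on that single result. The reported exposure of compound 2, 35800 ng.h/mL, is taken as the anchor, and a step of modest size in either direction, or none beyond the usual scatter, is as likely as any. For compound 4 the expected value in this assay is estimated at 20000 ng.h/mL, with a range from 5000 ng.h/mL to 60000 ng.h/mL.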

Compound 4, area under the concentration-time curve: 10600 ng.h/mL
Compound 4: middle estimate off by 1.9-fold (0.28 log units), on the high side; measured number inside the range.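

In this assay, the series now has its first readable step, a 3.4-fold lower number from compound 2 to compound 4 (0.53 log units; beyond the scatter). For the compounds shown here, at this position, configuration on the 4-methoxycyclohexyl ring is therefore enough on its own to move the number beyond the scatter, something no earlier compound could show. The step can be assigned to configuration alone because the comparison changes nothing else: the fact that compounds 2 and 4 differ only in the configuration as drawn

The change from cyclohexylmethyl to 4-methoxycyclohexyl cannot be read, as compound 3 has no single number here, and the same holds for the step involving compound 1. Going by these compounds, whether the same dependence on configuration would hold with another substituent at the same ring carbon, such as a hydroxyl or an amine in place of the methoxy group, remains open.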